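Urea nitrogen methylation in the phenylimidazole propoxy series

The source may report more compounds than this note shows. Statements on the series, on what has been measured and on what is new or still open speak of the compounds shown alone.

Compound 1 `CCNC(=O)Nc1c(OCCCn2cnc(-c3ccccc3)c2)cccc1N(C)C` gives 870 nM in an assay for inhibition of acyl-CoA:cholesterol acyltransferase (Oryctolagus cuniculus), using microsomes; on this read-out higher numbers stand for weaker inhibition and lower numbers for stronger inhibition. Compound 2 `CCCCCNC(=O)Nc1c(OCCCn2cnc(-c3ccccc3)c2)cccc1N(C)C` gives 31 nM in this assay and stands at the lowest of the two numbers, separated from the other by a 28-fold lower number from compound 1 to compound 2 (1.45 log units; beyond the scatter). Compound 3 `CCCCCN(C)C(=O)Nc1c(OCCCn2cnc(-c3ccccc3)c2)cccc1N(C)C` carries methyl in place of hydrogen on an amide-type nitrogen. For the measured compounds named here, the one measured step concerns the chain on the far side of the amide-type nitrogen, not the nitrogen itself, so its size gives no direct guide here. A moderate rise in number is expected, a 3.2-fold higher number from compound 2 to compound 3 (0.51 log units; beyond the scatter). For compound 3 the estimate is 100 nM, with a range from 20 nM to 600 nM.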

Compound 3, half-maximal inhibitory concentration: 550 nM
Compound 3: middle estimate off by 5.5-fold (0.74 log units), on the low side, within the range that was stated.
By their numbers in this assay, from the lowest: compound 2; then compounds 3 and 1 (each within the scatter of the next).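

In this assay the amide hydrogen on this nitrogen counts: methyl in its place gives an 18-fold higher number from compound 2 to compound 3 (1.25 log units; beyond the scatter) on the nitrogen itself, which the earlier chain step did not probe. With a 1.6-fold lower number from compound 1 to compound 3 (0.20 log units; within the scatter) the methyl(pentyl)amino and ethylamino groups on the carbonyl carbon cannot be told apart, so the pentyl chain keeps no clear gain once this nitrogen carries methyl. Nothing available explains this loss.

Open, going by these compounds, is whether ethyl on this nitrogen behaves like methyl. Also open, on these data alone, is whether methyl on the same nitrogen of compound 1 costs as much with the shorter ethyl chain.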